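The source may hold more compounds than are shown below. What is called first, only, known or untested is meant among the compounds shown, and "the series" means these compounds.

Measured compounds:
compound 1, `COc1cc(OC)c(C(=O)/C=C/c2ccc(Br)cc2)c(OC)c1`: 11300 nM in a functional assay on NCI-H727 cells (Homo sapiens) for cytotoxicity, with a stated time of 48 h; on this read-out higher numbers stand for weaker inhibition and lower numbers for stronger inhibition
compound 2, `COc1cc(O)c(C(=O)/C=C/c2ccccc2SC)c(OC)c1`: 9000 nM in this assay

Among the measured compounds shown here, of the two numbers so far in this assay, compound 1 gives the highest, and compound 2 stands nearest to it; the gap between them lies within the usual scatter of repeated measurements, so the two compounds cannot be placed in any order on these data. Compound 3, `COc1cc(OC)c(C(=O)/C=C/c2ccc(F)cc2)c(OC)c1`, has not yet been measured. It differs from compound 1 in one place: fluoro in place of bromo on an aromatic carbon. For the measured compounds named here, no step between measured compounds bears on this change, so the expectation for compound 3 rests on compound 1 alone. The change is expected to produce only a small step, a 1.2-fold higher number from compound 1 to compound 3 (0.09 log units; within the scatter), one that does not clearly go beyond the scatter in either direction. Compound 3 is therefore estimated at 14000 nM in this assay, with a range from 5000 nM to 45000 nM.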

Compound 3, half-maximal inhibitory concentration: 5500 nM
Beside the measured number, compound 3's estimate is 2.5-fold (0.41 log units) above it, and the stated range covers the measured number.
By their numbers in this assay, from the lowest: compounds 3, 2 and 1 (each within the scatter of the next, the first and the last beyond it).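

In this assay, among the compounds shown here, replacing bromo with fluoro on the aromatic carbon para to a large group gives a 2.1-fold lower number from compound 1 to compound 3 (0.31 log units; beyond the scatter), a modest step but the first comparison here in which only one place changes. It shows that the read-out responds to the group at this position, though the two halogens shift it only slightly, and that 4-fluorophenyl is the better of the two on the core of compound 1. Nothing available accounts for the step.

From the compounds shown here alone, with only bromo and fluoro at this position, it remains open whether the numbers follow any order across the halogens, as chloro or iodo could show. Whether a group of another kind, such as an amine, a methoxy or a carboxylic acid, would be tolerated there also stays unanswered.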